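From Isopropyl Amide to Cyclopropyl Urea on the Iodo Sulfonate

The compounds below may be only part of what the source reports. "The series", "measured", "known", "first", "only" and "open" are said of these compounds alone.

Compound 2 `CC(C)C(=O)Nc1ccc(S(=O)(=O)Oc2ccccc2I)cc1` gives 3300 nM in a functional assay on HT-1080 cells (Homo sapiens) for antiproliferative activity, read by sulforhodamine B assay, with a stated time of 48 h; on this read-out lower numbers stand for stronger inhibition and higher numbers for weaker inhibition. In this assay compound 1 `CC(C)C(=O)Nc1ccc(S(=O)(=O)Oc2ccccc2C(C)C)cc1` gives 4900 nM and compound 3 `CC(C)c1ccccc1OS(=O)(=O)c1ccc(NC(=O)NCCCCl)cc1` gives 2700 nM; all three numbers lie within the scatter of one another, so compound 2 stands among them without a separable place. Compound 4 `O=C(Nc1ccc(S(=O)(=O)Oc2ccccc2I)cc1)NC1CC1` differs from compound 2 by cyclopropylamino in place of isopropyl on a carbonyl carbon. Among the measured compounds shown here, the measured step that bears on this is a 1.8-fold lower number from compound 1 to compound 3 (0.26 log units; within the scatter), which likewise puts an amino group in place of isopropyl on a carbonyl carbon and stays within the scatter; a 1.5-fold lower number from compound 1 to compound 2 (0.17 log units; within the scatter) shows only that the change on the aromatic carbon was small. No step beyond the scatter is therefore expected in this assay, at most a slightly lower number. Compound 4 is estimated at 2500 nM, with a range from 1200 nM to 5200 nM. The expected step is a 1.3-fold lower number from compound 2 to compound 4 (0.12 log units; within the scatter).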

Compound 4, half-maximal inhibitory concentration: 1300 nM
Estimate against measurement, compound 4: 1.9-fold (0.28 log units) above; low and high end bracket the measured number.
By their numbers in this assay, from the lowest: compound 4; then compounds 3, 2 and 1 (each within the scatter of the next).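

On the iodo sulfonate, cyclopropylamino in place of isopropyl on a carbonyl carbon gives the only step beyond the scatter among these compounds in this assay (a 2.5-fold lower number from compound 2 to compound 4 (0.40 log units; beyond the scatter)). The amino replacement at this place in the other series stayed within the scatter (a 1.8-fold lower number from compound 1 to compound 3 (0.26 log units; within the scatter)), so a change here can separate compounds, though only modestly. Nothing measured here accounts for the step.

The compounds shown leave open whether the cyclopropyl ring or the added nitrogen matters more. Isopropylamino or cyclobutylamino at this place would test that on the same iodo sulfonate.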